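A few compounds are considered here, and "the series" means these few. Any claim that something is new, unique, unknown or untested is made for them only; others in the source may bear on it.

Measured compounds in an assay on isolated protein for inhibition of aldehyde dehydrogenase 1A1 (Homo sapiens), read by spectrophotometry, tested at 10 uM; a higher number here means more inhibition at the concentration tested (going by the name of the read-out), a lower number less inhibition:
- compound 1 `CC(C)Cn1c(CN2CCN(C(=O)C3CC3)CC2)nc2ccccc21` gives 13.1%
- compound 2 `Cc1ccccc1Cn1c(CN2CCN(C(=O)C3CC3)CC2)nc2ccccc21` gives 29.1%
- compound 3 `COc1cccc(Cn2c(CN3CCN(C(=O)C4CC4)CC3)nc3ccccc32)c1` gives 44.4%

Compound 3 stands highest of the three, with a number 15.3 percentage points higher from compound 2 to compound 3 (beyond the scatter) and a number 31.3 percentage points higher from compound 1 to compound 3 (beyond the scatter) both beyond the scatter. Compound 4 `O=C(C1CC1)N1CCN(Cc2nc3ccccc3n2Cc2ccccc2)CC1` differs from compound 3 by hydrogen in place of methoxy on an aromatic carbon. Among the compounds with values here, no measured step removes a methoxy directly, but the steps toward compound 3 both involve gaining the 3-methoxyphenyl, and a number 16 percentage points higher from compound 1 to compound 2 (beyond the scatter) shows an aryl group without methoxy giving a modest rise over isopropyl. Compound 4 is therefore expected to fall below compound 3, roughly to the level of compound 2, a step of a number 16.4 percentage points lower from compound 3 to compound 4 (beyond the scatter). Compound 4 is estimated at 28% in this assay, in the range 12% to 44%.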

Compound 4, a percentage reported as inhibition, at one concentration (the size of the read-out at that concentration, not a potency): 23.9%
Compound 4: middle estimate off by 4.1 percentage points, on the high side; low and high end bracket the measured number.
By their numbers in this assay, from the lowest: compound 1; then compounds 4 and 2 (each within the scatter of the next); then compound 3.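

In this assay the methoxy is now tested on its own, with the plain phenyl as the direct comparison: a number 20.5 percentage points lower from compound 3 to compound 4 (beyond the scatter). The methyl offers no such separation, with a number 5.2 percentage points lower from compound 2 to compound 4 (within the scatter). The bare phenyl still stands apart from isopropyl, with a number 10.8 percentage points higher from compound 1 to compound 4 (beyond the scatter), so part of the gain belongs to the aromatic ring and part to the methoxy.

Nothing available explains why the methoxy matters here. From the compounds shown here alone, it remains open whether an ethoxy, a hydroxy or a chlorine in that place would match the methoxy.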